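This account rests on a few compounds, and the source may have more. Where it says the series, first, only, none or still open, it means among the compounds named here.

Working notes on the series. Among the compounds with values here, compound 1 `COC(=O)c1ccc(-c2cnc(C(O)CCc3ccc(-c4ccccc4)cc3)o2)nc1` is the weaker of the two compounds measured so far: in an assay for inhibition of Fatty-acid amide hydrolase 1 (Rattus norvegicus) (on this read-out higher numbers stand for weaker inhibition and lower numbers for stronger inhibition), compound 1 gives 1100 nM. Compound 2 `COC(=O)c1cnc(C(=O)CCc2ccc(COc3ccccc3)cc2)o1` is the stronger one, and in this assay compound 2 gives 1.6 nM. On the two numbers recorded, compound 2 stands lowest, with compound 1 far above it and well beyond the scatter; the two structures differ in several places at once, so nothing about any single change can be drawn from that gap.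

Compound 3 `CN(C)C(=O)c1cnc(C(=O)CCc2ccc(COc3ccccc3)cc2)o1`, not yet measured, differs from compound 2 in one place only: dimethylamino in place of methoxy on a carbonyl carbon. Within the data shown here, no measured pair shows this kind of change, so the expectation rests on compound 2 alone, whose value of 1.6 nM sets the starting point. The change is expected to give a small step upward, a 3.1-fold higher number from compound 2 to compound 3 (0.49 log units; beyond the scatter), of a size that may not clear the scatter. Compound 3 is therefore estimated at 5 nM, with a plausible range from 1.5 nM to 20 nM.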

Compound 3, inhibition constant: 6.7 nM
Beside the measured number, compound 3's estimate is 1.3-fold (0.13 log units) below it; low and high end bracket the measured number.
By their numbers in this assay, from the lowest: compound 2; then compound 3; then compound 1.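

Within the data shown here, this is the first comparison that isolates a single change, at the carbonyl carbon whose other neighbour is an aromatic carbon: in this assay, dimethylamino in place of methoxy gives a 4.2-fold higher number from compound 2 to compound 3 (0.62 log units; beyond the scatter), a modest step that lies beyond the scatter. The change from methoxycarbonyl to dimethylcarbamoyl therefore costs something measurable at this place, yet compound 3 still gives 6.7 nM, so the methoxycarbonyl group is not required for a number of this order. Nothing on hand bears on why the number moves in this direction.

The compounds shown leave open whether this step is particular to dimethylamino or would hold for other groups on the same carbonyl carbon, such as amino, hydroxyl or a longer ethoxy chain. They also leave open whether the same change would give a step of similar size on the core of compound 1, which differs from compound 2 in several places at once.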